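Chloro to Cyano on Two Urea Cores

The source may hold more compounds than are shown below. What is called first, only, known or untested is meant among the compounds shown, and "the series" means these compounds.

Compound 1 `COc1ccc(CN(C(=O)Nc2ccc(Cl)cc2)n2cnnc2)cc1OC` is tested in a functional assay on B16-F10 cells (Mus musculus) for cytotoxicity, read by MTT assay, with a stated time of 48 h (on this read-out higher numbers stand for weaker inhibition and lower numbers for stronger inhibition), where compound 1 gives 42200 nM. Compound 2 `COc1ccc(CN(C(=O)Nc2ccc(C#N)cc2)n2cnnc2)cc1OC` carries cyano in place of chloro on an aromatic carbon. In this assay compound 2 reaches only a limit, > 50000 nM. That change made an at least 1.1-fold higher number from compound 1 to compound 2 (0.07 log units; that floor lies within the scatter). Compound 3 `Cc1ccsc1CN(C(=O)Nc1cccc(Cl)c1)n1cnnc1` rests on another core; the difference between the two cores is not broken down here. In this assay compound 3 reaches only a limit, > 50000 nM. Compound 4 `Cc1ccsc1CN(C(=O)Nc1cccc(C#N)c1)n1cnnc1` differs from compound 3 by cyano in place of chloro on an aromatic carbon, the same kind of change as between compound 1 and compound 2, though here the place is meta to a large group rather than para to a large group. Compound 4 is expected at 70000 nM. The expected step is a step that the limit leaves unreadable from compound 3 to compound 4, resting on the earlier step of an at least 1.1-fold higher number from compound 1 to compound 2 (0.07 log units; that floor lies within the scatter) and on (the limit of > 50000 nM in this assay, at which 2 of the 3 values shown sit).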

Compound 4, half-maximal inhibitory concentration: 28900 nM
Estimate against measurement, compound 4: 2.4-fold (0.38 log units) above, outside the stated range (below it).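

In this assay, cyano in place of chloro on the core of compound 3 gave an at least 1.7-fold lower number from compound 3 to compound 4 (0.23 log units; that floor lies within the scatter). Compound 3 itself has only a limit, > 50000 nM, so this step gives a floor and not a true size. Set beside the earlier step, it shows neither that the change carries over from one core to the other nor that it fails to: the same change on two cores in this assay, an at least 1.1-fold higher number (0.07 log units; that floor lies within the scatter) from compound 1 to compound 2 and an at least 1.7-fold lower number (0.23 log units; that floor lies within the scatter) from compound 3 to compound 4; the limit leaves it open whether they differ

The compounds shown leave open whether an amine or a carboxylic acid on that aromatic carbon would give a value clear of the limit on either core. Also open, from the compounds shown here alone, is how the 3-chlorophenyl and 3-cyanophenyl groups would read on the core of compound 1.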